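Benzyl to isopropyl on the side chain: working notes

A few compounds are considered here, and "the series" means these few. Any claim that something is new, unique, unknown or untested is made for them only; others in the source may bear on it.

Measured so far in an ADME assay on MDBK cells (Bos taurus) for cytotoxicity; a higher number here means that more compound is tolerated, a lower number that less compound is tolerated:
- Compound 1 `Fc1cccc(Cn2ccc3nc(-c4ccccc4)nc-3c2)c1`: > 100000 nM (a limit)
- Compound 2 `c1ccc(CCCn2ccc3nc(-c4ccccc4)nc-3c2)cc1`: > 100000 nM (a limit)

Compound 2 stands at > 100000 nM in this assay, and this is a limit. Compound 3 `CC(C)CCn1ccc2nc(-c3ccccc3)nc-2c1` carries isopropyl in place of benzyl on a saturated chain carbon, two bonds along the chain from an aromatic nitrogen. For the measured compounds named here, the only measured step is a step that the two limits leave unreadable from compound 1 to compound 2, so no size carries over. Both compound 1 and compound 2 fall under (the limit of > 100000 nM in this assay, at which 2 of the 2 values shown sit), so no step beyond the scatter is expected. The estimated step is a number no higher from compound 2 to compound 3 (the limit leaves the size open). For compound 3 the expected value is 100000 nM, with an estimated range of 50000 nM to 200000 nM.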

Compound 3, half-maximal cytotoxic concentration: > 100000 nM
Compound 3 was reported as a limit (the forecaster's own chance of this, stated with the estimate: 85%); the middle value lies on the limit itself.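

No step can be read among compound 1, compound 2 and compound 3 in this assay, because all three stand at the same limit: the limit of > 100000 nM in this assay, at which 3 of the 3 values shown sit.

The compounds shown leave open how much of each is actually tolerated, and whether benzyl and isopropyl differ at all on this chain.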